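The compounds below may be only part of what the source reports. "The series", "measured", "known", "first", "only" and "open" are said of these compounds alone.

Measured compounds in a functional assay on A549 cells (Homo sapiens) for cytotoxicity, read by MTT assay, with a stated time of 48 h; on this read-out higher numbers stand for weaker inhibition and lower numbers for stronger inhibition:
- compound 1 `O=c1ccoc2cc(OCc3cn(Cc4ccccc4F)nn3)ccc12`: 10800 nM
- compound 2 `N#Cc1ccc(Cn2cc(COc3ccc4c(=O)ccoc4c3)nn2)cc1`: in this assay compound 2 is reported only as a limit, > 100000 nM

Compound 2 therefore stands at the weak end of what the two measured values show; its number is a limit rather than a measured point, as noted in the limit of > 100000 nM in this assay, at which 1 of the 2 values shown sits. Among the compounds with values here, the one measured step, an at least 9.2-fold higher number from compound 1 to compound 2 (0.96 log units; beyond the scatter), runs toward this limit.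

Compound 3 `N#Cc1cccc(Cn2cc(COc3ccc4c(=O)ccoc4c3)nn2)c1` differs from compound 2 only in the position of the nitrile: 3-cyanophenyl in place of 4-cyanophenyl on a saturated chain carbon bound to an aromatic nitrogen. Within the data shown here, no measured step changes the position of a substituent on this phenyl ring, so the step from compound 1 to compound 2 gives only the level from which compound 3 starts, not the direction of the move. In this assay, compound 3 is expected to stay close to the limit seen for compound 2, with the step of an at least 1.1-fold lower number from compound 2 to compound 3 (0.04 log units; that floor lies within the scatter) not expected to go beyond the scatter. The estimate for compound 3 is 90000 nM, within 25000 nM to 300000 nM.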

Compound 3, half-maximal inhibitory concentration: 14300 nM
Beside the measured number, compound 3's estimate is 6.3-fold (0.80 log units) above it, and the stated range ends above it.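

In this assay, within the data shown here, the position of the nitrile on this phenyl ring makes a difference that the earlier compounds could not show: 3-cyanophenyl in place of 4-cyanophenyl gives an at least 6.9-fold lower number from compound 2 to compound 3 (0.84 log units; beyond the scatter). That step is only a floor, not a measured size, as its starting point is a limit for compound 2: the limit of > 100000 nM in this assay, at which 1 of the 3 values shown sits.

The weak level of 4-cyanophenyl therefore does not extend to every cyanophenyl group on this saturated chain carbon, and 3-cyanophenyl is not set apart from 2-fluorophenyl, with a 1.3-fold higher number from compound 1 to compound 3 (0.12 log units; within the scatter).

As far as these compounds go, the true size of the step from 4-cyanophenyl to 3-cyanophenyl remains open. Also open, from the compounds shown here alone, is whether a carboxylic acid or an amine at the 3-position of this phenyl ring would stay at the level of the nitrile.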